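The source may report more compounds than this note shows. Statements on the series, on what has been measured and on what is new or still open speak of the compounds shown alone.

Measured so far, all in a functional assay on the whole organism (strain Swiss albino) for inhibition, with Mus musculus as the target, in the formalin test, with stated times of 30 min and 5 min, at a dose of 100 mg/kg; a lower number here means less inhibition, a higher number more inhibition at the dose given (going by the name of the read-out):

Compound 1, `CCN1CCc2c(c(C)nn2C(=O)Nc2cc(C)ccc2C)C1`: 2.6%
Compound 2, `CCN1CCc2c(c(C)nn2C(=O)Nc2ccc(C)cc2C)C1`: 7%
Compound 3, `CCN1CCc2c(c(C)nn2C(=O)Nc2ccc(F)cc2F)C1`: 7.8%

All three compounds share one core and differ only in the substituted aromatic ring attached through the amide. In this assay compound 1 gives the lowest of the three numbers, yet the gap to compound 2 and the gap to compound 3 both lie within the usual scatter of repeated measurements, so the three values cannot be told apart with confidence; each of them signals only slight inhibition.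

Compound 4, `CCN1CCc2c(c(C)nn2C(=O)Nc2cc(C)ccc2F)C1`, has not yet been measured. Its structure is obtained from compound 1 by a single change: fluoro in place of methyl on an aromatic carbon. The new group sits ortho to a large group and para to a methyl group, as the count of the difference shows.

Among the compounds with values here, no step between two measured compounds is available to calibrate this change. With the three measured values so close together, no shift beyond the scatter is expected from compound 1 to compound 4; the estimated step is a number 2.4 percentage points higher from compound 1 to compound 4 (within the scatter). Compound 4 is therefore expected to give about 5%, between 0% and 14%.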

Compound 4, a percentage reported as inhibition, in the whole organism at one dose (the size of the read-out at that dose, not a potency): 5.2%
Compound 4: middle estimate off by 0.2 percentage points, on the low side; measured number inside the range.
By their numbers in this assay, from the lowest: compounds 1, 4, 2 and 3 (each within the scatter of the next).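

In this assay, putting fluoro in place of methyl on an aromatic carbon, ortho to a large group and para to a methyl group, gives a number 2.6 percentage points higher from compound 1 to compound 4 (within the scatter) and leaves the two compounds indistinguishable. Within the data shown here, this is the first comparison in the set in which only one place differs, so it isolates a single exchange in a way that the earlier compounds, which differ from one another in more than one place, could not: at this position and at this dose, methyl and fluoro cannot be told apart, and compound 1 at 2.6% and compound 4 at 5.2% both show only slight inhibition. No measured property of either group is available to account for this result.

The compounds shown leave open what an amine, a carboxylic acid or a longer chain at this same aromatic carbon would do to the number in this assay, and whether any such group would produce a step beyond the scatter. They also leave open whether fluoro in place of the other methyl group of compound 1 would likewise stay within the scatter.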